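Swapping a fluorophenyl for an ethylphenyl on sulfur

The source may report more compounds than this note shows. Statements on the series, on what has been measured and on what is new or still open speak of the compounds shown alone.

Compound 2 `Nc1ccccc1NC(=O)c1ccc(CSc2cccc(F)c2)cc1` was tested in a functional assay on SMMC-7721 cells (Homo sapiens) for inhibition, read by CCK-8 assay, with a stated time of 72 h, tested at 8 uM (a higher number here means more inhibition of growth at the concentration tested, a lower number less inhibition of growth), where compound 2 gives 83%. Compound 1 `Nc1ccccc1NC(=O)c1ccc(CSc2nccc(C(F)(F)F)n2)cc1` in this assay gives 80.6%, so compound 2 has the highest of the two numbers shown, although compound 1 sits within the scatter of it. Compound 3 `CCc1ccc(SCc2ccc(C(=O)Nc3ccccc3N)cc2)cc1` has not yet been measured. It differs from compound 2 by 4-ethylphenyl in place of 3-fluorophenyl on a sulfur. Among the compounds with values here, no measured pair shows what this kind of change does, so no step beyond the scatter in this assay is expected, in either direction. Compound 3 is estimated to give 80%, between 65% and 92%. This corresponds to an expected step of a number 3 percentage points lower from compound 2 to compound 3 (within the scatter).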

Compound 3, percent growth inhibition at one concentration: 82.9%
Beside the measured number, compound 3's estimate is 2.9 percentage points below it; low and high end bracket the measured number.
By their numbers in this assay, from the lowest: compounds 1, 3 and 2 (each within the scatter of the next).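

In this assay, placing 4-ethylphenyl instead of 3-fluorophenyl on this sulfur gives a number 0.1 percentage points lower from compound 2 to compound 3 (within the scatter). Within the data shown here, this is the first measured pair that differs in one place, and it shows that this change leaves the reading within the scatter. No measurement at hand explains this result.

From the compounds shown here alone, whether an amine, a carboxylic acid or a longer chain on this phenyl ring would also leave the reading within the scatter remains open. A reading at one concentration also cannot show whether compound 2 and compound 3 would match at other concentrations.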